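Methoxy analogue with a shorter chain: expected minimum effective dose

The source may hold more compounds than are shown below. What is called first, only, known or untested is meant among the compounds shown, and "the series" means these compounds.

Measured compounds:
Compound 1, `CCCc1cc(SC)nc2nc(C(=O)c3ccccc3)cn12`, 10 mg/kg in a functional assay on the whole organism with Rattus norvegicus as the target; on this read-out lower numbers stand for an effect already at smaller amounts and higher numbers for an effect only at larger amounts of compound.
Compound 2, `CSc1cc(C)n2cc(C(=O)c3ccccc3)nc2n1`, 5 mg/kg in this assay.
Compound 3, `CCCc1cc(OC)nc2nc(C(=O)c3ccccc3)cn12`, 1 mg/kg in this assay.

Compound 3 stands at the lowest number of the three: a 10-fold lower number from compound 1 to compound 3 (1.00 log units; beyond the scatter). The cores of compound 1 and compound 3 differ by methoxy in place of methylsulfanyl on an aromatic carbon. Within the core of compound 1, the change hydrogen in place of ethyl on a saturated chain carbon bound to an aromatic carbon gave a 2.0-fold lower number from compound 1 to compound 2 (0.30 log units; within the scatter).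

Compound 4, `COc1cc(C)n2cc(C(=O)c3ccccc3)nc2n1`, is not yet measured. It differs from compound 3 by hydrogen in place of ethyl on a saturated chain carbon bound to an aromatic carbon, the same change as from compound 1 to compound 2. Because that step was a 2.0-fold lower number from compound 1 to compound 2 (0.30 log units; within the scatter), only a small shift is expected from compound 3 to compound 4 in this assay, namely a 1.4-fold lower number from compound 3 to compound 4 (0.15 log units; within the scatter), which means compound 4 is estimated at 0.7 mg/kg, between 0.25 mg/kg and 2 mg/kg.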

Compound 4, minimum effective dose: 5 mg/kg
Compound 4: the middle estimate sits 7.1-fold (0.85 log units) below what was measured; the whole stated range lies below it.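

In this assay, replacing propyl with methyl gave a 5.0-fold higher number from compound 3 to compound 4 (0.70 log units; beyond the scatter), so this change did not carry over unchanged from one core to the other: the same change on two cores in this assay, a 2.0-fold lower number (0.30 log units; within the scatter) from compound 1 to compound 2 and a 5.0-fold higher number (0.70 log units; beyond the scatter) from compound 3 to compound 4, 10-fold (1.00 log units) apart, beyond the scatter of two such steps. Replacing methylsulfanyl with methoxy also depended on the core, giving no change at the digits printed from compound 2 to compound 4 (within the scatter): the same change on two cores in this assay, a 10-fold lower number (1.00 log units; beyond the scatter) from compound 1 to compound 3 and no change at the digits printed (within the scatter) from compound 2 to compound 4, 10-fold (1.00 log units) apart, beyond the scatter of two such steps. The four compounds show that neither change can be assumed to transfer within this set, but they do not show why the steps differ, and one pair of cores gives no rule for any other core.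

On these data alone, it remains open how a longer chain than propyl would behave on either core. As far as these compounds go, it is also open whether an amine in place of the methoxy would follow either pattern in this assay.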